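Bromo for methoxy at the aryl end of the chain

This account rests on a few compounds, and the source may have more. Where it says the series, first, only, none or still open, it means among the compounds named here.

Compound 2 `COc1ccc(NC(=O)CCCCCCNC(=O)C(O)(O)C(F)(F)F)cc1` and compound 1 `COc1ccc(-c2cnc(NC(=O)CCCCCCNC(=O)C(O)(O)C(F)(F)F)s2)cc1` share the same seven-carbon amide chain ending in the trifluoromethyl diol amide. In an assay on isolated protein for inhibition of histone deacetylase 4 (Homo sapiens), read by chemiluminescence, with a stated time of 3 h (a lower number here means a stronger inhibitor, a higher number a weaker inhibitor), compound 2 gives 1600000 nM, and compound 1 gives 2500000 nM; the two readings lie within the scatter of each other, so neither stands apart. Compound 3 `O=C(CCCCCCNC(=O)C(O)(O)C(F)(F)F)Nc1ccc(Br)cc1` carries bromo in place of methoxy on an aromatic carbon. Among the measured compounds shown here, no measured step speaks to such a swap, so the expectation for compound 3 rests only on the closely matched readings of compound 2 and compound 1. The step of no change at the digits printed from compound 2 to compound 3 (within the scatter) is expected to be none beyond the scatter. Compound 3 is therefore estimated at 1600000 nM, with a range from 500000 nM to 5000000 nM.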

Compound 3, half-maximal inhibitory concentration: 2600000 nM
The estimate for compound 3 lay 1.6-fold (0.21 log units) below the measured number, within the range that was stated.
By their numbers in this assay, from the lowest: compounds 2, 1 and 3 (each within the scatter of the next).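

Bromo in place of methoxy on an aromatic carbon, para to a large group, reads as a 1.6-fold higher number from compound 2 to compound 3 (0.21 log units; within the scatter) in this assay, so this assay does not tell the two groups apart at this position. Among the compounds shown here, this is the first single-place step. No measurement offered here explains the result.

As far as these compounds go, it remains open whether an amine or a carboxylic acid at this position would read beyond the scatter. From the compounds shown here alone, it also remains open whether a longer chain would shift the number with either the methoxy or the bromo group in place.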